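The source may hold more compounds than are shown below. What is called first, only, known or untested is meant among the compounds shown, and "the series" means these compounds.

Measured compounds:

Compound 1, `COc1cc(NC(C)CCCNC(=O)/C(C)=C/c2ccccc2)c2ncccc2c1`, gives > 100 ug/mL in an ADME assay on L6 cells (Rattus norvegicus) for cytotoxicity, read by resazurin assay, with a stated time of 70 h (on this read-out higher numbers stand for weaker inhibition and lower numbers for stronger inhibition), which is a limit of the assay rather than a number.

Compound 2, `COc1cc(NC(C)CCCNC(=O)/C=C/c2cc(OC)c(OC)c(OC)c2)c2ncccc2c1`, gives > 100 ug/mL in this assay, again a limit rather than a number.

Compound 1 thus stands at the limit of > 100 ug/mL in this assay, at which 2 of the 2 values shown sit, so its cytotoxicity towards these rat cells is too weak to be pinned down with a number here, and the same is true of compound 2. Compound 3, `COc1cc(NC(C)CCCNC(=O)/C=C/c2ccc(Cl)cc2)c2ncccc2c1`, has not yet been tested. It differs from compound 1 in one place: 2-(4-chlorophenyl)ethenyl in place of 1-methyl-2-phenylethenyl on a carbonyl carbon. Within the data shown here, no step between two measured compounds is available to guide the expectation, so the change from compound 1 to compound 3 in this assay is expected to be none beyond the scatter, a number no higher from compound 1 to compound 3 (the limit leaves the size open). For compound 3 the estimate in this assay is therefore 100 ug/mL, with a range from 40 ug/mL to 250 ug/mL, and most likely only a limit will be reported.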

Compound 3, half-maximal inhibitory concentration: 7.1 ug/mL
Beside the measured number, compound 3's estimate is 14-fold (1.15 log units) above it; the measured number lies below the stated range.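

In this assay the swap on the carbonyl carbon gives an at least 14-fold lower number from compound 1 to compound 3 (1.14 log units; beyond the scatter) and so shows that a change at this position can bring cytotoxicity towards these rat cells into measurable range, which two limits alone could not show. The two groups hold the same count of heavy atoms, so the step does not come with a larger group. On these data alone, its full size remains unknown, as compound 1 stands at a limit: the limit of > 100 ug/mL in this assay, at which 2 of the 3 values shown sit.

The change removes a methyl and adds a chlorine at once, so the compounds shown cannot tell which of the two carries the step. As far as these compounds go, the plain 2-phenylethenyl group, with neither methyl nor chlorine, would separate the two, and whether a bromine could stand in for the chlorine also stays open.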